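This account rests on a few compounds, and the source may have more. Where it says the series, first, only, none or still open, it means among the compounds named here.

Series notes. The shared core carries a trimethoxyphenyl group, a furyl group and a ketone whose far side is varied. Compound 1 `COc1cc(-c2nnc3n2NC(c2ccco2)C(C(=O)c2ccc(F)c(F)c2)S3)cc(OC)c1OC` bears a 3,4-difluorophenyl ketone; in a functional assay on MCF7 cells (Homo sapiens) for cytotoxicity, read by MTT assay, with a stated time of 48 h (on this read-out lower numbers stand for stronger inhibition and higher numbers for weaker inhibition), compound 1 gives 73200 nM. Compound 2 `COc1cc(-c2nnc3n2NC(c2ccco2)C(C(=O)C2CC2)S3)cc(OC)c1OC` carries a cyclopropyl ketone and in this assay compound 2 reaches only the limit of the assay, > 100000 nM. Compound 3 `COc1cc(-c2nnc3n2NC(c2ccco2)C(C(=O)c2ccc(C)cc2)S3)cc(OC)c1OC` carries a 4-methylphenyl ketone and in this assay compound 3 likewise stops at the assay limit, > 100000 nM. Compound 3 therefore stands at the limit of > 100000 nM in this assay, at which 2 of the 3 values shown sit, and no number is known for it. The measured steps are an at least 1.3-fold higher number from compound 1 to compound 2 (0.13 log units; that floor lies within the scatter), an at least 1.3-fold higher number from compound 1 to compound 3 (0.13 log units; that floor lies within the scatter) and a step that the two limits leave unreadable from compound 2 to compound 3; none of them is readable as a change beyond the scatter, and all three sit near or at the weak end of what this assay can report.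

Compound 4 `COc1cc(-c2nnc3n2NC(c2ccco2)C(C(=O)c2ccc(-c4ccccc4)cc2)S3)cc(OC)c1OC` differs from compound 3 by phenyl in place of methyl on an aromatic carbon. Among the measured compounds shown here, the only step that bears on it is the aryl variation an at least 1.3-fold higher number from compound 1 to compound 3 (0.13 log units; that floor lies within the scatter), which itself rests on a limit. With two of three neighbours at the limit, compound 4 is expected to remain at or near it in this assay, and the step that the limit leaves unreadable from compound 3 to compound 4 is estimated to be no more than scatter. For compound 4 the estimate in this assay is 150000 nM, within 50000 nM to 500000 nM.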

Compound 4, half-maximal inhibitory concentration: > 100000 nM
Compound 4: no number, only a limit; the forecaster's own chance of this, stated with the estimate: 70%; the middle value is on the limit's open side.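

Replacing methyl with phenyl, para to a large group, turns the 4-methylphenyl ketone into the 4-phenylphenyl ketone and still yields no number in this assay; this position has now carried both groups without a measured value appearing. Among the compounds shown here, the only readable comparison for the new compound is an at least 1.3-fold higher number from compound 1 to compound 4 (0.13 log units; that floor lies within the scatter) and it does not show a change beyond the scatter, while the steps among the compounds resting on limits cannot be read. The limit now describes most of the series, so the 3,4-difluorophenyl ketone is the only variation shown that gives a number: the limit of > 100000 nM in this assay, at which 3 of the 4 values shown sit.

From the compounds shown here alone, it remains open whether an amine or a carboxylic acid on the far side of the ketone would bring a value into the readable range of this assay. Also open, going by these compounds, is whether replacing the furyl group with a longer chain, or changing the trimethoxyphenyl group, would give numbers against which the ketone variations could be compared.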